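Compound 3 to compound 4: iodo replaced by an aryl group

The source may hold more compounds than are shown below. What is called first, only, known or untested is meant among the compounds shown, and "the series" means these compounds.

Values in a functional assay on MDA-MB-231 cells (Homo sapiens) for antiproliferative activity, read by MTT assay, with a stated time of 72 h; a lower number here means a stronger inhibitor, a higher number a weaker inhibitor:
Compound 1 `O=C(CCc1cccc2c1B(O)OC2)Nc1nccs1`: > 100000 nM (a limit)
Compound 2 `O=C(CCc1cccc2c1B(O)OC2)Nc1ccc(I)cc1`: 33000 nM
Compound 3 `O=C(CCc1cccc2c1B(O)OC2)Nc1cccc(I)c1`: 5300 nM

Compound 3, at 5300 nM, stands lowest of the two true numbers in this assay, with compound 2 nearest at 33000 nM. Compound 1 has no true number, and its > 100000 nM is a limit.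

Compound 4 `O=C(CCc1cccc2c1B(O)OC2)Nc1cccc(-c2cccc(Cl)c2)c1` is not yet measured. It differs from compound 3 as follows: 3-chlorophenyl in place of iodo on an aromatic carbon. The new group sits meta to a large group.

Going by the values given here, no measured step replaces the iodo itself, so the guidance is indirect. The nearest guide is a 6.2-fold lower number from compound 2 to compound 3 (0.79 log units; beyond the scatter), a modest step for 3-iodophenyl in place of 4-iodophenyl. The steps of an at least 3.0-fold lower number from compound 1 to compound 2 (0.48 log units; beyond the scatter) and an at least 18-fold lower number from compound 1 to compound 3 (1.27 log units; beyond the scatter) start from a limit and give only bounds, so they say little about the size of the next step. A modest step towards a lower number in this assay is therefore expected, although a step the other way cannot be excluded. The expected change is a 2.1-fold lower number from compound 3 to compound 4 (0.33 log units; beyond the scatter). For compound 4 the estimated value is 2500 nM, with an expected range of 600 nM to 10000 nM.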

Compound 4, half-maximal inhibitory concentration: 250 nM
For compound 4 the middle estimate is 10-fold (1.00 log units) above the measured one; measured number below the stated range.
By their numbers in this assay, from the lowest: compound 4; then compound 3; then compound 2. At a limit, above all of these: compound 1.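

In this assay, going by these compounds alone, the earlier compounds showed only that placement of the iodo matters, through a 6.2-fold lower number from compound 2 to compound 3 (0.79 log units; beyond the scatter) as the single step between two true numbers. Replacing the iodo itself now gives a 21-fold lower number from compound 3 to compound 4 (1.33 log units; beyond the scatter), so the group at this position, and not just where it sits on the ring, strongly shapes the antiproliferative read-out, with compound 4 at 250 nM holding the lowest number in the series. Nothing measured here accounts for the size of this step, which adds one six-membered aromatic ring of carbon only and a chlorine while adding no hydrogen-bond donors or acceptors.

Open, on these data alone, is whether the gain needs the chlorine or comes with the added ring alone, a question that a plain phenyl, or a phenyl carrying an amine or a carboxylic acid in place of the chlorine, would address. Also open, as far as these compounds go, is whether the 3-chlorophenyl would give a similar step at the place held by the iodo in compound 2, and whether the shared core contributes to the effect.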